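Benzofurazan in Place of Nitrophenyl on a Quinoxalinone Scaffold

The source may hold more compounds than are shown below. What is called first, only, known or untested is meant among the compounds shown, and "the series" means these compounds.

Compound 1 `O=c1c(-c2cccc([N+](=O)[O-])c2)nc2ccccc2n1Cc1ccccc1`: 9 nM
Compound 2 `COC(=O)c1ccc(N)c(-c2nc3ccccc3n(Cc3ccccc3)c2=O)c1`: 550 nM
Compound 3 `Nc1ccc(C(=O)O)cc1-c1nc2ccccc2n(Cc2ccccc2)c1=O`: limit, > 10000 nM

All three compounds share one core and were tested in an assay on cells for activation of Cystic fibrosis transmembrane conductance regulator (Homo sapiens), read by fluorescence, with a stated time of 10 min; on this read-out lower numbers stand for an effect already at smaller amounts and higher numbers for an effect only at larger amounts of compound. Compound 1 gives 9 nM, the lowest number among the measured values; the nearest measured neighbour is compound 2 with 550 nM, and that gap lies beyond the scatter. For compound 3 the assay reports only a limit, > 10000 nM. Within the data shown here, the single measured step concerns compound 2 and compound 3, which differ by a hydrogen in place of a methyl on an oxygen next to a carbonyl group, and it is large: an at least 18-fold higher number from compound 2 to compound 3 (1.25 log units; beyond the scatter). The limit of > 10000 nM in this assay, at which 1 of the 3 values shown sits, caps what that step can show.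

Compound 4 `O=c1c(-c2ccc3nonc3c2)nc2ccccc2n1Cc1ccccc1` is not yet measured. It differs from compound 1 at a different place than the measured step: a group of 9 heavy atoms (6 carbon, 2 nitrogen, 1 oxygen; one five-membered aromatic ring with 3 hetero atoms, one six-membered aromatic ring of carbon only) in place of a group of 9 heavy atoms (6 carbon, 1 nitrogen, 2 oxygen; one six-membered aromatic ring of carbon only), on an aromatic carbon, on an aromatic carbon. Among the measured compounds shown here, no measured step touches that position, so nothing here measures how this exchange moves the read-out. For the measured compounds named here, with only the step from compound 2 to compound 3 at another site, a modest weakening, within or just beyond the scatter, is expected: a 3.3-fold higher number from compound 1 to compound 4 (0.52 log units; beyond the scatter). Compound 4 is therefore estimated at 30 nM, with a likely range from 5 nM to 200 nM.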

Compound 4, half-maximal effective concentration: 18 nM
Compound 4: the middle estimate sits 1.7-fold (0.22 log units) above what was measured, and the stated range covers the measured number.
By their numbers in this assay, from the lowest: compounds 1 and 4 (each within the scatter of the next); then compound 2. At a limit, above all of these: compound 3.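

At the aromatic carbon of the shared core that carries the 3-nitrophenyl group in compound 1, no exchange had been measured until now, and in this assay this one gives a 2.0-fold higher number from compound 1 to compound 4 (0.30 log units; within the scatter). In this pair, then, the 3-nitrophenyl group can give way to a group with one five-membered aromatic ring with 3 hetero atoms and one six-membered aromatic ring of carbon only, and the number stays as low as before, so a low number at this position does not require a nitro group. Which feature shared by the two groups allows this cannot be told, as nothing measured here bears on that question.

The compounds shown leave open whether other groups at this position, such as a phenyl ring carrying a nitrile or a sulfonamide, or a simple pyridine ring, would also keep the number this low. From the compounds shown here alone, the benzyl group on the ring nitrogen is the same in all four compounds, so the effect of a longer chain or a plain methyl group there remains open as well.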